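Aromatic nitrogen substituent: step from compound 2 to compound 3

This account rests on a few compounds, and the source may have more. Where it says the series, first, only, none or still open, it means among the compounds named here.

Measured so far:
compound 1 `O=C1COCCN1c1ccc(/N=C\c2c[nH]c3ccccc23)cc1` gives 100% in an ADME assay on BV-2 cells (Mus musculus) for cytotoxicity, read by MTT assay, with a stated time of 48 h, tested at 15 uM; a higher number here means a weaker effect of the compound at the concentration tested, a lower number a stronger effect
compound 2 `O=C1COCCN1c1ccc(/N=C\c2cn(C(=O)c3ccc(Cl)cc3)c3ccccc23)cc1` gives 105% in this assay

In this assay the two numbers are indistinguishable within the scatter; compound 2 carries the numerically higher one. Among the compounds with values here, the single measured step is a number 5 percentage points higher from compound 1 to compound 2 (within the scatter), the change being (4-chlorophenyl)carbonyl in place of hydrogen on an aromatic nitrogen. Neither compound shows any loss of viability at the concentration tested.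

Compound 3 `O=C1COCCN1c1ccc(/N=C\c2cn(Cc3ccccc3)c3ccccc23)cc1` differs from compound 2 as follows: benzyl in place of (4-chlorophenyl)carbonyl on an aromatic nitrogen. The measured step concerns the same aromatic nitrogen but a different entering group, so it bears on the present change only in a general way: it shows that placing a large group on that nitrogen left this assay unchanged. Nothing among the shown compounds points to a benzyl group acting differently here. The step from compound 2 to compound 3 is therefore expected to stay within the scatter, a number 5 percentage points lower from compound 2 to compound 3 (within the scatter).

For compound 3 the value in this assay is estimated at 100%, with a range of 85% to 115%.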

Compound 3, a percentage reported as activity, at one concentration (the size of the read-out at that concentration, not a potency): 95.7%
Beside the measured number, compound 3's estimate is 4.3 percentage points above it, and the stated range covers the measured number.
By their numbers in this assay, from the lowest: compounds 3, 1 and 2 (each within the scatter of the next).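

In this assay, the aromatic nitrogen now has three different occupants whose readings cannot be separated: benzyl in place of (4-chlorophenyl)carbonyl gives a number 9.3 percentage points lower from compound 2 to compound 3 (within the scatter), and benzyl in place of hydrogen gives a number 4.3 percentage points lower from compound 1 to compound 3 (within the scatter). The earlier pair covered only hydrogen and (4-chlorophenyl)carbonyl on this nitrogen, whereas compound 3 extends the same reading to a group with no carbonyl and no chlorine, so among these compounds neither feature of the group that leaves is needed for this result. The data give no reason why the three compounds read alike.

As far as these compounds go, whether the same holds for a substituent carrying an amine or a carboxylic acid, or for a longer chain linking the phenyl ring to that nitrogen, remains open. Also open, from the compounds shown here alone, is how compound 1, compound 2 and compound 3 would read at other concentrations, since each reading here comes from a single concentration and time.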